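A few compounds are considered here, and "the series" means these few. Any claim that something is new, unique, unknown or untested is made for them only; others in the source may bear on it.

Of the compounds shown here, three of the shared core have been measured in an assay on HEK293 cells for displacement of a labelled ligand from NPC1-like intracellular cholesterol transporter 1 (Homo sapiens); a higher number here means a weaker inhibitor, a lower number a stronger inhibitor. Compound 1 `O=C(CN1CN(c2ccccc2)C2(CCN(C(=O)c3ccc(C4CCCCC4)cc3)CC2)C1=O)NCCCCO` gives 10300 nM. Compound 2 `CC(C)(C)OC(=O)NCCCCCNC(=O)CN1CN(c2ccccc2)C2(CCN(C(=O)c3ccc(C(C)(C)C)cc3)CC2)C1=O` gives 13700 nM, and compound 3 `CCOC(=O)C1CCN(C(=O)CN2CN(c3ccccc3)C3(CCN(C(=O)c4ccc(C(C)(C)C)cc4)CC3)C2=O)CC1` gives 3100 nM. Among these three numbers compound 1 stands second highest. Its number and that of compound 2 lie within the scatter of each other, so no order is read between them, whereas compound 3 lies beyond the scatter below compound 1. For the measured compounds named here, no two of the measured compounds differ in one place only, so no single step between measured compounds can be read.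

The next compound, compound 4 `CC(C)(C)OC(=O)NCCCCNC(=O)CN1CN(c2ccccc2)C2(CCN(C(=O)c3ccc(C4CCCCC4)cc3)CC2)C1=O`, is reached from compound 1 by one change: (tert-butoxycarbonyl)amino in place of hydroxy on a saturated chain carbon, four bonds along the chain from an amide-type nitrogen. The entering group already occurs in compound 2, which in this assay gives 13700 nM, a number within the scatter of compound 1. On that basis the step from compound 1 to compound 4 is expected to be a 1.1-fold higher number from compound 1 to compound 4 (0.03 log units; within the scatter), that is, nothing beyond the scatter in either direction. Compound 4 is accordingly estimated at 11000 nM, with a range from 4000 nM to 30000 nM.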

Compound 4, half-maximal inhibitory concentration: 4600 nM
Compound 4: middle estimate off by 2.4-fold (0.38 log units), on the high side; the range from low to high includes it.
By their numbers in this assay, from the lowest: compounds 3 and 4 (each within the scatter of the next); then compounds 1 and 2 (each within the scatter of the next).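

In this assay, the side chain of the shared core now gives its first readable single step: (tert-butoxycarbonyl)amino in place of hydroxy on a saturated chain carbon, four bonds along the chain from an amide-type nitrogen, gives a 2.2-fold lower number from compound 1 to compound 4 (0.35 log units; beyond the scatter), a modest step beyond the scatter. For the compounds shown here, at this place, a group of 8 heavy atoms replaces a group of 1 heavy atom and the number falls, which the earlier compounds could not show, as none of them differed from another in one place only. No measurement at hand bears on the origin of this step.

From the compounds shown here alone, with a single step at this place, it remains open whether the lower number belongs to the whole (tert-butoxycarbonyl)amino group or to its nitrogen alone, a question that a free amine or an acetamide on the same chain carbon would address. Also open, going by these compounds, are how a carboxylic acid at this place would read, and whether the same change gives a step of similar size on a longer chain or with tert-butyl in place of cyclohexyl on the benzoyl group.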